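This account rests on a few compounds, and the source may have more. Where it says the series, first, only, none or still open, it means among the compounds named here.

Compound 1, `COc1ncc(-c2ccc3nc(NC(=O)NCCN4CCCC4)sc3c2)cc1NS(=O)(=O)c1ccc(F)cc1`: 410 nM
Compound 2, `CCN(CC)CCNC(=O)Nc1nc2ccc(-c3cnc(OC)c(NS(=O)(=O)c4ccc(F)cc4)c3)cc2s1`: 320 nM
Compound 3, `COc1ncc(-c2ccc3nc(NC(=O)NC4CC4)sc3c2)cc1NS(=O)(=O)c1ccc(F)cc1`: 1190 nM

In a functional assay on MCF7 cells (Homo sapiens) for antiproliferative activity, read by MTT assay, with a stated time of 72 h (on this read-out lower numbers stand for stronger inhibition and higher numbers for weaker inhibition), compound 3 stands highest of the three numbers, with compound 1 nearest and compound 2 furthest. The two steps that reach compound 3 both point the same way: a 2.9-fold higher number from compound 1 to compound 3 (0.46 log units; beyond the scatter) and a 3.7-fold higher number from compound 2 to compound 3 (0.57 log units; beyond the scatter), while the exchange of one amine-bearing chain for the other, a 1.3-fold lower number from compound 1 to compound 2 (0.11 log units; within the scatter), stays within the scatter.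

Compound 4, `CNC(=O)Nc1nc2ccc(-c3cnc(OC)c(NS(=O)(=O)c4ccc(F)cc4)c3)cc2s1`, differs from compound 3 by methyl in place of cyclopropyl on an amide-type nitrogen. Within the data shown here, no measured step compares a methyl with a cyclopropyl here; the only steps that bear on it show that losing the 2-(pyrrolidin-1-yl)ethyl or 2-(diethylamino)ethyl chain in favour of cyclopropyl raised the number modestly, and compound 4 likewise carries neither chain. With no guide for the methyl itself, compound 4 is expected to land close to compound 3, with a 1.1-fold higher number from compound 3 to compound 4 (0.04 log units; within the scatter) expected to stay within the scatter. Compound 4 is therefore estimated at 1300 nM, between 550 nM and 3200 nM.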

Compound 4, half-maximal inhibitory concentration: 1190 nM
Estimate against measurement, compound 4: 1.1-fold (0.04 log units) above; the range from low to high includes it.
By their numbers in this assay, from the lowest: compounds 2 and 1 (each within the scatter of the next); then compounds 3 and 4 (each within the scatter of the next).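

In this assay, putting methyl in place of cyclopropyl on the amide-type nitrogen gives no change at the digits printed from compound 3 to compound 4 (within the scatter), so no difference between these two small groups can be read at this position. Methyl sits as far from the amine-bearing chains as cyclopropyl does, with a 3.7-fold higher number from compound 2 to compound 4 (0.57 log units; beyond the scatter) and a 2.9-fold higher number from compound 1 to compound 4 (0.46 log units; beyond the scatter), which leaves the two chains in one group and the two small substituents in another. Nothing measured here explains this separation.

From the compounds shown here alone, whether a longer chain without an amine, a 2-hydroxyethyl chain or a carboxylic acid on the same nitrogen would match compound 1 and compound 2 remains open. So does whether the amine or the length of the chain goes with their lower numbers, as both chains differ from methyl and cyclopropyl in both respects.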